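Swapping the Methylsulfanyl Branch of Compound 2 for Cyclopentenyl

The compounds below may be only part of what the source reports. "The series", "measured", "known", "first", "only" and "open" are said of these compounds alone.

Three measured compounds share one core and differ only at the end of the chain. In an assay (Equus caballus) for inhibition of Thromboxane-A synthase (Homo sapiens), using microsomes (a higher number here means a weaker inhibitor, a lower number a stronger inhibitor), compound 1 `NC(=O)CCCC/C=C(\c1ccccc1)c1cccnc1` gives 400 nM. Compound 2 `CSC(CCC/C=C(\c1ccccc1)c1cccnc1)C(=O)O` gives 30 nM, the lowest of the three numbers, and compound 3 `CCOC(=O)CCCC/C=C(\c1ccccc1)c1cccnc1` gives 600 nM. The two steps around compound 2, a 13-fold lower number from compound 1 to compound 2 (1.12 log units; beyond the scatter) and a 20-fold higher number from compound 2 to compound 3 (1.30 log units; beyond the scatter), show that the carboxylic acid carrying a methylsulfanyl branch gives a far lower number than the unbranched amide or ester, while a 1.5-fold higher number from compound 1 to compound 3 (0.18 log units; within the scatter). Compound 4 `O=C(O)C(CCC/C=C(\c1ccccc1)c1cccnc1)C1=CCCC1` keeps the acid but has cyclopent-1-en-1-yl in place of methylsulfanyl on a saturated chain carbon bound to a carbonyl carbon and a saturated chain carbon. Among the compounds with values here, no measured step tests a change of the branch itself, so the step of a 1.5-fold lower number from compound 2 to compound 4 (0.18 log units; within the scatter) is expected to be small. Compound 4 is therefore estimated at 20 nM, within 5 nM to 80 nM.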

Compound 4, half-maximal inhibitory concentration: 60 nM
Estimate against measurement, compound 4: 3.0-fold (0.48 log units) below, and the stated range covers the measured number.
By their numbers in this assay, from the lowest: compounds 2 and 4 (each within the scatter of the next); then compounds 1 and 3 (each within the scatter of the next).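

The branch on this carbon can change a good deal without moving the number beyond the scatter: with the carboxylic acid kept, cyclopent-1-en-1-yl replacing methylsulfanyl gives a 2.0-fold higher number from compound 2 to compound 4 (0.30 log units; within the scatter). So neither the sulfur nor the open shape of the methylsulfanyl branch is needed for a number in this range in this assay. No evidence here explains why the two branches read alike. Still open, on these data alone, is what a phenyl branch or plain hydrogen on this carbon would give, and so whether any branch matters beside the carboxylic acid.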